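The compounds below may be only part of what the source reports. "The series", "measured", "known", "first", "only" and "open" are said of these compounds alone.

Compound 1 `CCCCCCSC[C@H]1C2CCC(O2)[C@H]1C/C=C\CCCC(=O)O`: in a functional assay on a cell-free system (plasma) for inhibition of thromboxane A2 receptor (Homo sapiens) (a higher number here means a weaker inhibitor, a lower number a stronger inhibitor), compound 1 gives 3800 nM.
Compound 2 `CCCCCCSC[C@H]1C2CC[C@@H](O2)[C@H]1C/C=C\CCCC(=O)O`: compound 2 gives 115000 nM; > 1000000 nM; > 1000000 nM (3 entries) over several entries.
Compound 3 `CSCSCC1C2CCC(O2)C1C/C=C\CCCC(=O)O`: compound 3 gives 700 nM.

Compound 3 stands at the lowest of the two numbers in this assay; compound 1 sits at a higher number, beyond the usual scatter, and compound 2 is known only through entries that are mostly limits. Compound 4 `CCCCSCSCC1C2CCC(O2)C1C/C=C\CCCC(=O)O` differs from compound 3 by propyl in place of hydrogen on a saturated chain carbon bound to a sulfur. Within the data shown here, no measured pair isolates this change. The step of a 1.4-fold lower number from compound 3 to compound 4 (0.15 log units; within the scatter) is estimated to stay within the scatter, with no clear direction. Compound 4 is expected to give about 500 nM, within a range of 120 nM to 2500 nM.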

Compound 4, half-maximal inhibitory concentration: 700 nM
For compound 4 the middle estimate is 1.4-fold (0.15 log units) below the measured one; measured number inside the range.
By their numbers in this assay, from the lowest: compounds 3 and 4 (each within the scatter of the next); then compound 1.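

In this assay, among these compounds, the change of methylsulfanyl to butylsulfanyl gives no change at the digits printed from compound 3 to compound 4 (within the scatter) and this is the only measured pair that isolates a change at this place. On a saturated chain carbon bound to a sulfur, propyl in place of hydrogen is therefore tolerated in this pair, with the added carbons leaving the read-out where it stood.

On these data alone, whether a longer chain such as octyl, a phenyl ring or an amine at this place would hold the same level remains open. Nothing on hand bears on why this step is flat.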